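Adding a Second Chloro Group to Compound 1

The source may report more compounds than this note shows. Statements on the series, on what has been measured and on what is new or still open speak of the compounds shown alone.

For the measured compounds named here, in a functional assay (aorta) for inhibition, with Rattus norvegicus as the target (a lower number here means a stronger inhibitor, a higher number a weaker inhibitor), compound 1 `Cc1nsc(-c2ccc(N3CCN(c4cccc(Cl)c4)CC3)nn2)n1` gives 0.6 nM, the lowest of the three numbers measured so far. Compound 2 `Cc1nsc(-c2ccc(N3CCN(c4cccc(C(F)(F)F)c4)CC3)nc2)n1` gives 5 nM and compound 3 `CCc1nsc(-c2ccc(N3CCN(c4cccc(C(F)(F)F)c4)CC3)nn2)n1` gives 8 nM, both higher than compound 1 by more than the scatter. Going by the values given here, these three compounds differ from one another in more than one place, so no measured pair isolates a single change. Compound 4 `Cc1nsc(-c2ccc(N3CCN(c4cc(Cl)cc(Cl)c4)CC3)nn2)n1` takes compound 1 from 3-chlorophenyl to 3,5-dichlorophenyl, with chloro in place of hydrogen on an aromatic carbon. In this assay, the expected step of a 1.7-fold higher number from compound 1 to compound 4 (0.22 log units; within the scatter) is small, towards a higher number, and within the scatter. For compound 4, the estimated value is 1 nM, with an expected range of 0.25 nM to 4 nM.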

Compound 4, half-maximal inhibitory concentration: < 0.1 nM
Compound 4: only a limit was reported; the forecaster's own chance of this, stated with the estimate: 3%; middle value at least 10-fold (1.00 log units) away from the limit.
By their numbers in this assay, from the lowest: compound 1; then compounds 2 and 3 (each within the scatter of the next). At a limit, below all of these: compound 4.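

Going from 3-chlorophenyl to 3,5-dichlorophenyl gives an at least 6.0-fold lower number from compound 1 to compound 4 (0.77 log units; beyond the scatter) in this assay, the first comparison here that isolates a single change. It shows that this aromatic carbon accepts a chloro group in place of hydrogen with no loss, and with a gain beyond the scatter. Compound 4 gives < 0.1 nM, which is a limit and not a number, so the full size of the step cannot be read: the limit of < 0.1 nM in this assay, at which 1 of the 4 values shown sits.

From the compounds shown here alone, what a methyl group, a methoxy group or an amine would do at this position stays open. So does whether a second chloro group would have a similar effect on the trifluoromethyl compounds, compound 2 and compound 3.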